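Chloro in Place of Methyl: What to Expect for Compound 3

The source may hold more compounds than are shown below. What is called first, only, known or untested is meant among the compounds shown, and "the series" means these compounds.

Within the data shown here, compound 1 `C=CCn1c(=O)/c(=C\c2cccc(C)c2)[nH]c(=O)/c1=C\c1ccccc1OC` is the only member of this small set with a number in a functional assay on MOLT-4 cells (Homo sapiens) for cytotoxicity, read by CCK-8 assay, with a stated time of 72 h; on this read-out higher numbers stand for weaker inhibition and lower numbers for stronger inhibition: compound 1 gives 16000 nM, a weak result. Compound 2 `COc1ccccc1/C=c1\c(=O)[nH]/c(=C/c2ccccc2Cl)c(=O)n1C` has no reported value there; in this assay compound 2 stands as "not determined" (no result reported). Compound 3 `C=CCn1c(=O)/c(=C\c2cccc(Cl)c2)[nH]c(=O)/c1=C\c1ccccc1OC` differs from compound 1 by a single change, (chloro in place of methyl on an aromatic carbon). Among the measured compounds shown here, no measured step of this kind is available, so the step in this assay is expected to be small, in either direction, and not beyond the usual scatter. Compound 3 is therefore expected to give about 12000 nM, between 4000 nM and 40000 nM. The expected step is a 1.3-fold lower number from compound 1 to compound 3 (0.12 log units; within the scatter).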

Compound 3, half-maximal inhibitory concentration: 4900 nM
Estimate against measurement, compound 3: 2.4-fold (0.39 log units) above; the range from low to high includes it.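

In this assay, among these compounds, going from 3-methylphenyl to 3-chlorophenyl gives a 3.3-fold lower number from compound 1 to compound 3 (0.51 log units; beyond the scatter), the first measured step at this place. It shows that this aromatic carbon, meta to a large group, responds to a single-atom exchange by more than the usual scatter, though only modestly. Nothing in the data shown accounts for the step.

From the compounds shown here alone, whether a bromo, an amine or a carboxylic acid at this place would lower the number further remains open. So does whether the same exchange would give a similar step with other groups elsewhere on the shared core.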